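The source may report more compounds than this note shows. Statements on the series, on what has been measured and on what is new or still open speak of the compounds shown alone.

Measured so far in a physicochemical assay for solubility, in simulated intestinal fluid, with a stated time of 4 h; on this read-out lower numbers stand for lower solubility and higher numbers for higher solubility:
compound 1 `N#Cc1ccc(O[C@H]2CN(S(=O)(=O)c3ccc(Cl)cc3Cl)C[C@@]2(O)CO)cc1F`: 19 ug/mL
compound 2 `N#Cc1ccc(O[C@H]2CN(S(=O)(=O)c3ccc(Cl)cn3)C[C@@]2(O)CO)cc1F`: 26 ug/mL
compound 3 `N#Cc1ccc(S(=O)(=O)[C@H]2CN(S(=O)(=O)c3ccc(Cl)cn3)C[C@@]2(O)CO)cc1`: > 1000 ug/mL, which is a limit of this assay and not a number.

The step of a 1.4-fold lower number from compound 2 to compound 1 (0.14 log units; within the scatter) is the change (2,4-dichlorophenyl in place of 5-chloropyridin-2-yl on a sulfonyl sulfur). Compound 2 and compound 3 share no counted difference; how their two cores differ is not broken down here, and their values simply show compound 3 at the limit of > 1000 ug/mL in this assay, at which 1 of the 3 values shown sits, while compound 2 gives a number.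

Compound 4 `N#Cc1ccc(S(=O)(=O)[C@H]2CN(S(=O)(=O)c3ccc(Cl)cc3Cl)C[C@@]2(O)CO)cc1` is not yet measured in this assay. It differs from compound 3 by 2,4-dichlorophenyl in place of 5-chloropyridin-2-yl on a sulfonyl sulfur, the same change as from compound 2 to compound 1. Because that earlier step a 1.4-fold lower number from compound 2 to compound 1 (0.14 log units; within the scatter) stayed within scatter, the step of an at least 1.3-fold lower number from compound 3 to compound 4 (0.12 log units; that floor lies within the scatter) is expected to be small. Compound 4 is therefore estimated at 750 ug/mL, between 250 ug/mL and 1500 ug/mL, with a fair chance that only a limit is again reported.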

Compound 4, solubility: 270 ug/mL
For compound 4 the middle estimate is 2.8-fold (0.44 log units) above the measured one; the range from low to high includes it.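

In this assay the same change, 2,4-dichlorophenyl in place of 5-chloropyridin-2-yl on a sulfonyl sulfur, gives a 1.4-fold lower number from compound 2 to compound 1 (0.14 log units; within the scatter) on one core and an at least 3.7-fold lower number from compound 3 to compound 4 (0.56 log units; beyond the scatter) on the other, so a step within the scatter on one core did not stay within it on the other. In this assay compound 3 gives > 1000 ug/mL, which is a limit and not a number. The step on the second core is thus only a floor, its true size stays unknown, and two pairs set no rule for other cores: the limit of > 1000 ug/mL in this assay, at which 1 of the 4 values shown sits.

The compounds shown compare only two groups on the sulfonyl sulfur. As far as these compounds go, how an amine or a carboxylic acid on that aryl group would read in this assay remains open.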